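Halogen swap on the benzyl group of a hydroxycinnamamide series

The source may hold more compounds than are shown below. What is called first, only, known or untested is meant among the compounds shown, and "the series" means these compounds.

Of the compounds shown here, three that share one core have been measured in an assay on isolated protein for inhibition of Amine oxidase [flavin-containing] A (Homo sapiens), read by fluorescence, with stated times of 15 min and 20 min; a lower number here means a stronger inhibitor, a higher number a weaker inhibitor. Compound 1 `CC(C)(C)c1cc(/C=C/C(=O)NCCC2CCN(Cc3ccccc3)CC2)cc(C(C)(C)C)c1O` gives 62300 nM. Compound 2 `CC(C)(C)c1cc(/C=C/C(=O)NCCC2CCN(Cc3cccc(F)c3)CC2)cc(C(C)(C)C)c1O` gives 58400 nM, and compound 3 `CC(C)(C)c1cc(/C=C/C(=O)NCCC2CCN(Cc3ccc(F)cc3)CC2)cc(C(C)(C)C)c1O` gives 59600 nM. Compound 3 stands among its two neighbours: from compound 2 the step is a 1.0-fold higher number from compound 2 to compound 3 (0.01 log units; within the scatter), and from compound 1 it is a 1.0-fold lower number from compound 1 to compound 3 (0.02 log units; within the scatter), so the three numbers are not separated from one another.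

Compound 4 `CC(C)(C)c1cc(/C=C/C(=O)NCCC2CCN(Cc3cccc(Cl)c3)CC2)cc(C(C)(C)C)c1O` differs from compound 3 in a single respect: 3-chlorophenyl in place of 4-fluorophenyl on a saturated chain carbon bound to an amine nitrogen in a ring. Two kinds of measured step bear on this change. Placing a fluorine on the aromatic ring gave a 1.1-fold lower number from compound 1 to compound 2 (0.03 log units; within the scatter) and a 1.0-fold lower number from compound 1 to compound 3 (0.02 log units; within the scatter); moving that fluorine from one position to the other gave a 1.0-fold higher number from compound 2 to compound 3 (0.01 log units; within the scatter). All three steps lie within the scatter, so no step beyond the scatter is expected in this assay for a chlorine entering at the position of the fluorine of compound 2.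

Compound 4 is therefore expected to give about 58000 nM, between 28000 nM and 120000 nM, which is an expected step of a 1.0-fold lower number from compound 3 to compound 4 (0.01 log units; within the scatter).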

Compound 4, half-maximal inhibitory concentration: 65100 nM
Estimate against measurement, compound 4: 1.1-fold (0.05 log units) below, within the range that was stated.
By their numbers in this assay, from the lowest: compounds 2, 3, 1 and 4 (each within the scatter of the next).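

In this assay, a heavier halogen on the benzyl group separates nothing: chloro in place of hydrogen (a 1.0-fold higher number from compound 1 to compound 4 (0.02 log units; within the scatter)), chloro in place of fluoro on an aromatic carbon (a 1.1-fold higher number from compound 2 to compound 4 (0.05 log units; within the scatter)) and 3-chlorophenyl in place of 4-fluorophenyl (a 1.1-fold higher number from compound 3 to compound 4 (0.04 log units; within the scatter)) all stay within the scatter. The flat picture that compounds 1, 2 and 3 gave for fluorine therefore also holds for chlorine, and all four compounds remain within the scatter of one another. No measurement shown here offers an explanation for this flatness.

The compounds shown leave open whether any group other than a halogen on this benzyl ring, such as an amine, a carboxylic acid or a methoxy group, would move the number beyond the scatter. They also leave open what 4-chlorobenzyl would give.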